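The compounds below may be only part of what the source reports. "The series", "measured", "known", "first", "only" and "open" are said of these compounds alone.

Among the compounds with values here, compound 1 `C=CCn1c(=O)/c(=C\c2cccc(C)c2)[nH]c(=O)/c1=C\c1ccccc1OC` is the only member of the series with a number against it: in a functional assay on K562 cells (Homo sapiens) for cytotoxicity, read by CCK-8 assay, with a stated time of 72 h (on this read-out higher numbers stand for weaker inhibition and lower numbers for stronger inhibition), compound 1 gives 8800 nM. Compound 2 `COc1ccccc1/C=c1/[nH]c(=O)/c(=C\c2ccccc2OC)[nH]c1=O` is recorded in this assay as "not active" (no number reported), with no number to set beside it. Compound 3 `C=CCn1c(=O)/c(=C\c2ccc(F)c(Br)c2)[nH]c(=O)/c1=C\c1ccccc1OC` remains to be measured in this assay; it differs from compound 1 by 3-bromo-4-fluorophenyl in place of 3-methylphenyl on a double-bonded chain carbon bound to an aromatic carbon. Within the data shown here, no pair of measured compounds differing in one place is available, so this change has no precedent; a shift near or within the usual scatter, with no firm direction, is expected. Compound 3 is therefore estimated at 6500 nM, with a range of 2000 nM to 25000 nM. That estimate corresponds to an expected step of a 1.4-fold lower number from compound 1 to compound 3 (0.13 log units; within the scatter).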

Compound 3, half-maximal inhibitory concentration: "not active" (no number reported)
Compound 3: no number reported, and the estimate cannot be compared.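

In this assay, within the data shown here, compound 3 carries no number, so no step from compound 1 to compound 3 can be read. No measured evidence bears on this result. From the compounds shown here alone, what the 3-bromo-4-fluorophenyl group does to the number of compound 1 stays open.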